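A few compounds are considered here, and "the series" means these few. Any claim that something is new, unique, unknown or untested is made for them only; others in the source may bear on it.

In a functional assay on COLO 205 cells (Homo sapiens) for inhibition, read by sulforhodamine B assay, with a stated time of 48 h, tested at 50 uM (on this read-out lower numbers stand for less inhibition of growth and higher numbers for more inhibition of growth at the one concentration tested), compound 2 `COc1cc(/C=C/C(=O)/C=C/c2cc(OC)c(OC)c(OC)c2)ccc1OCc1cn(CCOc2cc(=O)oc3ccccc23)nn1` gives 86%. Compound 1 `COc1cc(/C=C/C(=O)/C=C/c2cccs2)ccc1OCc1cn(CCOc2cc(=O)oc3ccccc23)nn1` differs from it by one change, (thiophen-2-yl in place of 3,4,5-trimethoxyphenyl on a double-bonded chain carbon bound to a double-bonded chain carbon), and in this assay compound 1 gives 66%, so the step of a number 20 percentage points lower from compound 2 to compound 1 (beyond the scatter) was measured. Compound 3 `COc1cc(/C=C/C(=O)/C=C/c2cc(OC)c(OC)c(OC)c2)ccc1OCc1cn(CCCOc2cc(=O)oc3ccccc23)nn1` has a different core; how its core differs from that of compound 2 is not broken down here. In this assay compound 3 gives 74%. Compound 4 `COc1cc(/C=C/C(=O)/C=C/c2cccs2)ccc1OCc1cn(CCCOc2cc(=O)oc3ccccc23)nn1` is not yet measured and differs from compound 3 by thiophen-2-yl in place of 3,4,5-trimethoxyphenyl on a double-bonded chain carbon bound to a double-bonded chain carbon, the same change as seen between compound 2 and compound 1. A similar step is expected from compound 3 to compound 4, namely a number 20 percentage points lower from compound 3 to compound 4 (beyond the scatter), because of the step of a number 20 percentage points lower from compound 2 to compound 1 (beyond the scatter). In this assay compound 4 is estimated at 54%. The expected range for compound 4 runs from 40% to 68%.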

Compound 4, percent growth inhibition at one concentration: 55%
Beside the measured number, compound 4's estimate is 1 percentage points below it; the range from low to high includes it.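

In this assay, putting thiophen-2-yl in place of 3,4,5-trimethoxyphenyl gives a number 19 percentage points lower from compound 3 to compound 4 (beyond the scatter). For the compounds shown here, the change carried over from one core to the other with much the same size: the same change on two cores in this assay, a number 20 percentage points lower (beyond the scatter) from compound 2 to compound 1 and a number 19 percentage points lower (beyond the scatter) from compound 3 to compound 4, 1 percentage points apart, within the scatter of two such steps This rests on only two pairs of compounds tested at a single concentration, so it does not show that the step would hold on other cores, nor does it explain why the number falls.

The compounds shown leave open what other groups in this place, such as an amine or a carboxylic acid, would do to the inhibition of growth. They also leave open whether the step would stay the same with a longer chain in the core.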